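Enlarging the Carboxamide-Bearing Ring on the Shared Core

The compounds below may be only part of what the source reports. "The series", "measured", "known", "first", "only" and "open" are said of these compounds alone.

In an assay on isolated protein for inhibition of protein kinase C theta type (Homo sapiens), read by TR-FRET, with a stated time of 2 h (on this read-out higher numbers stand for weaker inhibition and lower numbers for stronger inhibition), compound 3 `N#Cc1cnc(NCc2ccccc2C(F)(F)F)cc1N[C@H]1C[C@@H](C(N)=O)C1` gives 150 nM, the highest of the three numbers recorded so far. Compound 1 `N#Cc1cnc(NCc2ccccc2C(F)(F)F)cc1N[C@H]1CC[C@@H](O)CC1` gives 140 nM, and the step of a 1.1-fold higher number from compound 1 to compound 3 (0.03 log units; within the scatter) lies within the scatter, so these two cannot be told apart. For the measured compounds named here, compound 2 `CO[C@H]1CC[C@@H](Nc2cc(NCc3cnccc3C(F)(F)F)ncc2C#N)CC1` gives 58 nM, a number that sits beyond the scatter below that of compound 3; no single-point step connects these two. Compound 4 `N#Cc1cnc(NCc2ccccc2C(F)(F)F)cc1N[C@H]1CC[C@@H](C(N)=O)CC1` differs from compound 3 by 4-carbamoylcyclohexyl in place of 3-carbamoylcyclobutyl on a nitrogen on an aromatic ring. Going by the values given here, only the step from compound 1 to compound 3 bears on this change: it exchanged a six-membered ring carrying a hydroxyl for a four-membered ring carrying a carboxamide, and the number stayed within the scatter. Returning to a six-membered ring, now carrying the carboxamide, is therefore expected to give a step of a 1.3-fold lower number from compound 3 to compound 4 (0.10 log units; within the scatter) that again stays within the scatter. Compound 4 is estimated at 120 nM, with a likely range from 50 nM to 300 nM.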

Compound 4, half-maximal inhibitory concentration: 20 nM
Compound 4: middle estimate off by 6.0-fold (0.78 log units), on the high side; the whole stated range lies above it.
By their numbers in this assay, from the lowest: compound 4; then compound 2; then compounds 1 and 3 (each within the scatter of the next).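

The step from compound 1 to compound 3 changed the ring and its group together, so its flat result said little about either change alone. Compound 4 separates them: with the carboxamide kept, the larger ring gives a 7.5-fold lower number from compound 3 to compound 4 (0.88 log units; beyond the scatter), and with the six-membered ring kept, carbamoyl in place of hydroxy gives a 7.0-fold lower number from compound 1 to compound 4 (0.85 log units; beyond the scatter), so each change alone moves the number beyond the scatter, although together they did not. No measurement here explains why either change has this effect.

From the compounds shown here alone, it remains open whether a carboxylic acid or an amine in place of carbamoyl on the saturated ring carbon would match compound 4. A five-membered ring carrying the carboxamide is also an open case, as is whether the same carbamoyl exchange would lower the number on the core of compound 2.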